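One Flipped Stereocentre Starting from Compound 2

A few compounds are considered here, and "the series" means these few. Any claim that something is new, unique, unknown or untested is made for them only; others in the source may bear on it.

In a functional assay on NCI-H1299 cells (Homo sapiens) for cytotoxicity, read by MTT assay, with a stated time of 24 h (on this read-out higher numbers stand for weaker inhibition and lower numbers for stronger inhibition), compound 1 `CC(=O)O[C@@]1(C)C/C=C2\O[C@H](C[C@@H]2C)C[C@]2(C)O[C@H]2C(=O)C(=C(C)C)CC1` gives 28300 nM and compound 2 `CC(=O)O[C@@]1(C)CCC(=O)[C@H](C)CCC[C@]2(C)O[C@H]2C(=O)C(=C(C)C)CC1` gives 19500 nM as its value, and these two numbers lie within the usual scatter of each other. Compound 3 `CC(C)=C1CC[C@]2(C)CC[C@]3(O[C@H](C[C@H]3C)C[C@]3(C)O[C@H]3C1=O)O2` shows > 50000 nM as a limit of the assay and not as a number. Compound 2 therefore cannot be separated from compound 1 on these results. Compound 4 `CC(=O)O[C@@]1(C)CCC(=O)[C@@H](C)CCC[C@]2(C)O[C@H]2C(=O)C(=C(C)C)CC1` has the same atoms and bonds as compound 2, with the two compounds have the same atoms and bonds and differ only in configuration as drawn: 1 of 4 stereo elements differ; a stereocentre at a saturated ring carbon is drawn R in compound 2 and S in compound 4 as the only difference: a stereocentre at a saturated ring carbon is drawn R in compound 2 and S in compound 4. Among the compounds with values here, no measured pair shows what such a change does here, so no shift beyond the scatter is expected. The estimated 1.2-fold higher number from compound 2 to compound 4 (0.09 log units; within the scatter) is accordingly small and has no firm direction. The expected value for compound 4 is 24000 nM with a range of 9000 nM to 50000 nM around it.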

Compound 4, half-maximal inhibitory concentration: 17200 nM
Estimate against measurement, compound 4: 1.4-fold (0.14 log units) above; low and high end bracket the measured number.
By their numbers in this assay, from the lowest: compounds 4, 2 and 1 (each within the scatter of the next). At a limit, above all of these: compound 3.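

Setting this saturated ring carbon as S rather than R now has a measured result, which the earlier compounds could not provide. In this assay, the change (a 1.1-fold lower number from compound 2 to compound 4 (0.05 log units; within the scatter)) cannot be told apart from ordinary repeat scatter. For this pair, the drawn configuration at this position therefore produces no detectable shift in the cytotoxicity read-out.

Still open, on these data alone, is whether replacing the methyl group on this carbon with an ethyl group, a longer chain or an amine would move the number. As far as these compounds go, the effect of the same configurational change on other cell lines also remains unknown.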